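Amino in place of chloro on compound 2

This account rests on a few compounds, and the source may have more. Where it says the series, first, only, none or still open, it means among the compounds named here.

In a functional assay on the whole organism (strain Sprague-Dawley) for inhibition, with Rattus norvegicus as the target, with a stated time of 10 min (on this read-out lower numbers stand for an effect already at smaller amounts and higher numbers for an effect only at larger amounts of compound), compound 1 (`O=C(O)c1cnc(-c2ccccc2OCc2ccccc2)[nH]c1=O`) gives 5 mg/kg and compound 2 (`CCOc1ccc(Cl)cc1-c1ncc(C(=O)O)c(=O)[nH]1`) gives 0.5 mg/kg as the lower of the two numbers, a gap beyond the usual scatter. Compound 3 (`CCOc1ccc(N)cc1-c1ncc(C(=O)O)c(=O)[nH]1`) has not yet been measured and differs from compound 2 at one place: amino in place of chloro on an aromatic carbon with amino in place of chloro on an aromatic carbon, para to an ethoxy group. Among the compounds with values here, no measured pair shows this exchange, so any expectation is rough. Compound 2 at 0.5 mg/kg already holds the lower number, and in this assay a moderate step upward is expected rather than a further drop. The expected change a 3.0-fold higher number from compound 2 to compound 3 (0.48 log units; beyond the scatter) is an estimate with wide margins. Compound 3 is estimated at 1.5 mg/kg with 0.3 mg/kg to 8 mg/kg as its expected range.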

Compound 3, dose for 50% inhibition: 1.2 mg/kg
Estimate against measurement, compound 3: 1.3-fold (0.10 log units) above, within the range that was stated.
By their numbers in this assay, from the lowest: compound 2; then compound 3; then compound 1.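

In this assay, within the data shown here, the exchange of amino for chloro, para to an ethoxy group, gives a 2.4-fold higher number from compound 2 to compound 3 (0.38 log units; beyond the scatter) and is the first measured change at this position. The step lies beyond the scatter, so the position is sensitive to this change and chloro gives the lower number, yet the amino group, which brings a hydrogen-bond donor and acceptor that chloro lacks, costs only a modest step, and compound 3 still gives 1.2 mg/kg in this whole-animal read-out. No measurement shown explains why the step has this size or direction.

The compounds shown leave open how a plain hydrogen, a fluoro or a dimethylamino group would fare at this position. They also leave open whether a methoxy group in place of the ethoxy group would change the size of this step.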